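The compounds below may be only part of what the source reports. "The series", "measured", "known", "first", "only" and "open" are said of these compounds alone.

Measured in a functional assay on THP-1 cells (Homo sapiens) for inhibition; on this read-out lower numbers stand for stronger inhibition of growth and higher numbers for weaker inhibition of growth:
- Compound 1 `Cc1noc(C)c1-c1ccc2c(c1)c(Cc1ccccc1)cn2CCCCCCC(=O)NO`: 15500 nM
- Compound 2 `Cc1cccc(Cc2cn(CCCCCC(=O)NO)c3ccc(-c4c(C)noc4C)cc23)c1`: 15500 nM

Compound 2 stands level with compound 1, and the two values lie within the scatter of repeated measurements. Compound 3 `Cc1cccc(Cc2cn(CCCCCCC(=O)NO)c3ccc(-c4c(C)noc4C)cc23)c1` has not yet been measured. It differs from compound 2 in one place: (hydroxycarbamoyl)methyl in place of hydroxycarbamoyl on a saturated chain carbon, five bonds along the chain from an aromatic nitrogen. In words, (hydroxycarbamoyl)methyl stands in place of hydroxycarbamoyl on a saturated chain carbon, five bonds along the chain from an aromatic nitrogen. Going by the values given here, no measured step shows this change directly. With compound 1 at 15500 nM and compound 2 at 15500 nM, nothing in the numbers points in either direction, so no step beyond the scatter is expected in this assay. The estimated step is a 1.0-fold lower number from compound 2 to compound 3 (0.01 log units; within the scatter). In this assay the estimate for compound 3 is 15000 nM, with an expected range from 6500 nM to 33000 nM.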

Compound 3, concentration for 50% growth inhibition: 15500 nM
The estimate for compound 3 lay 1.0-fold (0.01 log units) below the measured number; the measured number falls inside the stated range.
By their numbers in this assay, from the lowest: compounds 1, 2 and 3 (each within the scatter of the next).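

Compounds 1 and 2 differ in two places, so their matching values could not show what either change does alone. In this assay, (hydroxycarbamoyl)methyl in place of hydroxycarbamoyl on a saturated chain carbon, five bonds along the chain from an aromatic nitrogen, gives no change at the digits printed from compound 2 to compound 3 (within the scatter) and methyl in place of hydrogen on an aromatic carbon gives no change at the digits printed from compound 1 to compound 3 (within the scatter) as the second single change, so each change taken alone stays within the scatter. No supporting measurement here offers an explanation for this result.

As far as these compounds go, whether a longer chain, such as 5-(hydroxycarbamoyl)pentyl, would also stay within the scatter remains open. So does the outcome of a carboxylic acid in place of the hydroxycarbamoyl end, or of chlorine in place of that methyl.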